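Amide nitrogen substituent swap in an aryl-linked diamine series

The source may hold more compounds than are shown below. What is called first, only, known or untested is meant among the compounds shown, and "the series" means these compounds.

Measured so far:
compound 1 `COc1cc(NC(=O)c2cncc(N3CC4CC(C3)N4)c2)cc(OC)c1` — 2000 nM
compound 2 `O=C(NCc1ccccc1)c1cncc(N2CC3CC(C2)N3)c1` — 1600 nM

In an assay on cells for displacement of a labelled ligand from Neuronal acetylcholine receptor; alpha3/beta4 (Homo sapiens) (a lower number here means a stronger inhibitor, a higher number a weaker inhibitor), compound 1 gives 2000 nM and compound 2 gives 1600 nM. Within this pair of numbers compound 2 sits where the gap to compound 1 lies inside the scatter of repeated measurements, so no order between the two can be read from this assay; both are moderate binders.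

The next compound, compound 3 `COc1cccc(NC(=O)c2cncc(N3CC4CC(C3)N4)c2)c1`, keeps the shared core and changes only the group on the amide nitrogen: 3-methoxyphenyl in place of benzyl on an amide-type nitrogen. Compound 1 already carries an aryl group in place of the benzyl, and in this assay compound 1 gives 2000 nM, a number within the scatter of compound 2. Among the compounds with values here, nothing among the measured compounds suggests that the move to an aryl amide with one methoxy group shifts binding beyond the scatter. The expectation is therefore a step of a 1.1-fold higher number from compound 2 to compound 3 (0.05 log units; within the scatter) in this assay, which is no real change. Compound 3 is estimated at 1800 nM, with a range from 800 nM to 4000 nM.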

Compound 3, inhibition constant: 265 nM
Estimate against measurement, compound 3: 6.8-fold (0.83 log units) above; measured number below the stated range.
By their numbers in this assay, from the lowest: compound 3; then compounds 2 and 1 (each within the scatter of the next).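

In this assay, the group on the amide-type nitrogen proves able to move binding beyond the scatter: 3-methoxyphenyl in place of benzyl gives a 6.0-fold lower number from compound 2 to compound 3 (0.78 log units; beyond the scatter) at this position. The aryl amide alone does not set the number, as hydrogen in place of methoxy on an aromatic carbon gives a 7.5-fold lower number from compound 1 to compound 3 (0.88 log units; beyond the scatter) and so shows that the substitution on the aryl ring also counts. The data shown offer no measurement that accounts for either step.

The compounds shown do not separate the contribution of the single methoxy group from that of the aryl ring directly attached to the amide-type nitrogen, and an unsubstituted phenyl, a 3-hydroxyphenyl or a 3-chlorophenyl at this position would bear on that question. On these data alone, it also remains open whether the same gain would appear with a 3-methoxybenzyl group, or whether a non-aromatic substituent such as a longer chain ending in an amine could keep binding at this nitrogen.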